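Methyl on the phenol oxygen: compound 1 to compound 3

This account rests on a few compounds, and the source may have more. Where it says the series, first, only, none or still open, it means among the compounds named here.

Compound 1 `O=C(Nc1cccc(-n2cc(-c3ccncc3)c(-c3cc(O)cc(Cl)c3)n2)c1)Nc1ccc(Cl)c(Cl)c1` and compound 2 `COc1cc(Cl)cc(-c2nn(-c3cccc(NC(=O)Nc4cc(C(F)(F)F)cc(C(F)(F)F)c4)c3)cc2-c2ccncc2)c1` share the same core and differ in the aryl urea and in the substituent on the oxygen. In a functional assay on K562 cells (Homo sapiens) for inhibition, read by sulforhodamine B assay, with a stated time of 48 h, tested at 0.1 uM (a lower number here means a stronger effect, a higher number a weaker effect of the compound at the concentration tested), compound 1 gives 100%. In this assay compound 2 gives 91%, so compound 1 stands at the higher of the two readings, while the gap between them lies within the scatter. Compound 3 `COc1cc(Cl)cc(-c2nn(-c3cccc(NC(=O)Nc4ccc(Cl)c(Cl)c4)c3)cc2-c2ccncc2)c1` has not yet been measured in this assay. It differs from compound 1 by methyl in place of hydrogen on an oxygen on an aromatic ring, and its aryl urea is the same as that of compound 1. Within the data shown here, no step between measured compounds isolates this change. Since compound 1 gives 100% and compound 2, which carries the methoxy, gives 91%, the step expected for compound 3 is a number 4 percentage points lower from compound 1 to compound 3 (within the scatter), that is, none beyond the scatter. For compound 3 the estimated reading is 96%, with a range from 82% to 106%.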

Compound 3, a percentage reported as activity, at one concentration (the size of the read-out at that concentration, not a potency): 58%
The estimate for compound 3 lay 38 percentage points above the measured number; the whole stated range lies above it.
By their numbers in this assay, from the lowest: compound 3; then compounds 2 and 1 (each within the scatter of the next).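

In this assay, the change from hydroxy to methoxy on the shared core, with the aryl urea of compound 1 kept, is a large step: a number 42 percentage points lower from compound 1 to compound 3 (beyond the scatter). At the concentration tested, the methoxy compound therefore has the stronger effect. This position responds to the addition of a single methyl, which the two earlier compounds could not show, since they differ in both the aryl urea and the substituent on the oxygen. Nothing measured here explains the step.

Going by these compounds, whether the effect is specific to methoxy remains open, as does how an ethoxy group, a benzyloxy group or an amine at this position would read. On these data alone, compound 2 carries the same methoxy with a different aryl urea and gives 91%, so it also remains open whether the step carries over to other aryl ureas.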